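Side-chain swap on the shared core: cytotoxicity outlook

The source may hold more compounds than are shown below. What is called first, only, known or untested is meant among the compounds shown, and "the series" means these compounds.

Within the data shown here, compound 2 `O=C1CSC(=O)N1C[C@H]1CN(c2ccc(-n3cc(-c4ccccn4)cn3)c(F)c2)C(=O)O1` has the highest number of the two measured so far in an ADME assay on HEK293-A cells (Homo sapiens) for cytotoxicity, read by MTT assay, with a stated time of 48 h (on this read-out higher numbers stand for weaker inhibition and lower numbers for stronger inhibition), giving 283 ug/mL; compound 1 `COC(=O)CC1CCN(C[C@H]2CN(c3ccc(-n4cc(-c5ccccn5)cn4)c(F)c3)C(=O)O2)CC1` gives 224 ug/mL, and the step of a 1.3-fold higher number from compound 1 to compound 2 (0.10 log units; within the scatter) lies within the scatter. Compound 3 `O=C1O[C@@H](CSc2cccs2)CN1c1ccc(-n2cc(-c3ccccn3)cn2)c(F)c1` is not yet measured. The change is (thiophen-2-yl)sulfanyl in place of 2,4-dioxo-1,3-thiazolidin-3-yl on a saturated chain carbon bound to a saturated ring carbon. Among the measured compounds shown here, only one measured step touches the same position, namely a 1.3-fold higher number from compound 1 to compound 2 (0.10 log units; within the scatter), and it shows that exchanging the group on that carbon gave a number within the scatter of the starting point. For the measured compounds named here, with only that step to go on, the expectation for compound 3 is no step beyond the scatter, an estimated step of a 1.1-fold lower number from compound 2 to compound 3 (0.05 log units; within the scatter). Compound 3 is therefore estimated at 250 ug/mL in this assay, with an expected range from 120 ug/mL to 450 ug/mL.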

Compound 3, half-maximal inhibitory concentration: > 400 ug/mL
Compound 3: no number, only a limit (the forecaster's own chance of this, stated with the estimate: 15%); middle value at least 1.6-fold (0.20 log units) away from the limit.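

In this assay compound 3 reads > 400 ug/mL, which is a limit and not a number, and it extends this position to a (thiophen-2-yl)sulfanyl group, with one five-membered aromatic ring in place of the earlier groups. Against the earlier compounds, the change reads as an at least 1.4-fold higher number from compound 2 to compound 3 (0.15 log units; that floor lies within the scatter) and as an at least 1.7-fold higher number from compound 1 to compound 3 (0.25 log units; that floor lies within the scatter), so neither step is shown to pass the scatter, although either may be larger than its floor. The full size of both steps stays out of reach for one reason: the limit of > 400 ug/mL in this assay, at which 1 of the 3 values shown sits.

As far as these compounds go, it remains open whether the aromatic ring or the sulfur link governs the reading in compound 3. A primary amine or a carboxylic acid on this saturated chain carbon would show whether the number can move beyond the scatter in the lower direction.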